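Cytotoxicity Outlook From Compound 3 to Compound 4

The compounds below may be only part of what the source reports. "The series", "measured", "known", "first", "only" and "open" are said of these compounds alone.

Compound 1 `COC(=O)c1cc2c(Nc3ccc(OC(F)(F)F)cc3)ncnc2s1`: > 10000 nM
Compound 2 `CS(=O)(=O)c1cccc(-c2cc(Nc3ccc(OC(F)(F)F)cc3)ncn2)c1`: > 10000 nM
Compound 3 `FC(F)(F)Oc1ccc(Nc2cc(-c3cn[nH]c3)ncn2)cc1`: > 10000 nM

In an ADME assay on BaF3 cells (Mus musculus) for cytotoxicity (a lower number here means that less compound is needed, a higher number that more compound is needed for the effect), compound 1 gives only a limit, > 10000 nM. Compound 2 likewise gives a limit, > 10000 nM. Compound 3 also sits at a limit, > 10000 nM, so no number is known for it. Every value shown rests at the limit of > 10000 nM in this assay, at which 3 of the 3 values shown sit.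

Compound 4 `FC(F)(F)Oc1ccc(Nc2cc(-c3ccnc4[nH]ccc34)ncn2)cc1` differs from compound 3 by a group of 9 heavy atoms (7 carbon, 2 nitrogen; one five-membered aromatic ring with 1 hetero atom, one six-membered aromatic ring with 1 hetero atom) in place of a group of 5 heavy atoms (3 carbon, 2 nitrogen; one five-membered aromatic ring with 2 hetero atoms), on an aromatic carbon. With no measured step between any two of these compounds, the account offers no step to build on; the three limits give no direction. The step from compound 3 to compound 4 in this assay is therefore expected to be none beyond the scatter, a step that the limit leaves unreadable from compound 3 to compound 4. Compound 4 is estimated at 15000 nM, within 5000 nM to 50000 nM, most likely reported again as a limit.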

Compound 4, half-maximal effective concentration: 6850 nM
Estimate against measurement, compound 4: 2.2-fold (0.34 log units) above; the measured number falls inside the stated range.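

In this assay, going by these compounds alone, compound 4 gives 6850 nM as the first number in this set. The other compounds remain at a limit: (the limit of > 10000 nM in this assay, at which 3 of the 4 values shown sit). At this place, on an aromatic carbon of the six-membered aromatic ring with 2 nitrogen, replacing 1H-pyrazol-4-yl with the larger group of two aromatic rings gives an at least 1.4-fold lower number from compound 3 to compound 4 (0.16 log units; that floor lies within the scatter) and thus sets only a floor for the step.

On these data alone, the true size of that step remains open. So does whether a phenyl or a morpholine at this place would also give a number rather than a limit.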